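Swapping Cyano for Chloro on a Mast Cell Inhibitor

The compounds below may be only part of what the source reports. "The series", "measured", "known", "first", "only" and "open" are said of these compounds alone.

Compound 1 `N#Cc1ccc2oc(C(=O)Nc3nnn[nH]3)cc(=O)c2c1`: 2.3 ug/mL
Compound 2 `O=C(O)c1ccc2occc(=O)c2c1`: > 18 ug/mL
Compound 3 `O=C(Cl)c1coc2ccccc2c1=O`: "nd(insoluble)" (no result reported)

Three compounds were tested in a functional assay on cells (Mast cell, Rattus norvegicus) for inhibition, with a stated time of 15 min; a lower number here means that less compound is needed, a higher number that more compound is needed for the effect. Within the data shown here, compound 1 is the only one that gave a number, namely 2.3 ug/mL. For compound 2 the assay reports only a limit, > 18 ug/mL, and not a number; this is the limit described in the limit of > 18 ug/mL in this assay, at which 1 of the 3 values shown sits. Compound 3 gave no result at all, its entry reading "nd(insoluble)" (no result reported). So compound 1 stands alone as the one compound with a measured concentration, and no step between two measured compounds can be drawn from these data.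

The new compound is compound 4 `O=C(Nc1nnn[nH]1)c1cc(=O)c2cc(Cl)ccc2o1`. It keeps the core of compound 1 and differs in one place: chloro in place of cyano on an aromatic carbon. Among the measured compounds shown here, no pair of measured compounds shows what such a swap does here, so the expectation rests on compound 1 alone. Cyano and chloro are both small groups on the same aromatic carbon, and without a measured step to point to, the change is expected to stay within the usual scatter of this assay, with at most a slight shift toward more compound being needed.

Compound 4 is therefore estimated to give 3 ug/mL, between 1 ug/mL and 9 ug/mL, which means an expected step of a 1.3-fold higher number from compound 1 to compound 4 (0.12 log units; within the scatter).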

Compound 4, concentration for half-maximal effect: 0.75 ug/mL
Compound 4: the middle estimate sits 4.0-fold (0.60 log units) above what was measured, and the stated range ends above it.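

In this assay, the swap of cyano for chloro on this aromatic carbon gives a 3.1-fold lower number from compound 1 to compound 4 (0.49 log units; beyond the scatter) and is the first measured step in the set, so the position is shown to respond to what sits on it. Since a lower number means that less compound is needed, the cyano group, with its triple bond and its hydrogen-bond acceptor, is not required for the effect, and a single chlorine atom serves better in this assay. Nothing shown measures a property of either group that would account for the size of this step, so the data record the change without giving a reason for it.

Still open, going by these compounds, is whether other groups on this same carbon, such as a methoxy group, an amine or a carboxylic acid, would lower the number further than chloro does or raise it again. Also open, on these data alone, is what a plain hydrogen at this place would give on the shared core, which would show whether any group is needed here at all.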